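From Compound 2 to Compound 3: A Sulfonyl Aryl Swap

The source may hold more compounds than are shown below. What is called first, only, known or untested is meant among the compounds shown, and "the series" means these compounds.

In a functional assay on LNCaP cells (Homo sapiens) for antiproliferative activity, read by propidium iodide staining, with a stated time of 96 h (on this read-out higher numbers stand for weaker inhibition and lower numbers for stronger inhibition), compound 1 (`CC(O)(CS(=O)(=O)c1ccc(F)cc1)C(=O)Nc1cccc(S(F)(F)(F)(F)F)c1`) gives 32600 nM and compound 2 (`CC(O)(CS(=O)(=O)c1ccccc1C(F)(F)F)C(=O)Nc1cccc(S(F)(F)(F)(F)F)c1`) gives 24900 nM as its value. These two values lie within the scatter of each other (a 1.3-fold lower number from compound 1 to compound 2 (0.12 log units; within the scatter)), so compound 2 stands level with compound 1. Compound 3 (`CC(O)(CS(=O)(=O)c1ccc(OC(F)(F)F)cc1)C(=O)Nc1cccc(S(F)(F)(F)(F)F)c1`) carries 4-(trifluoromethoxy)phenyl in place of 2-(trifluoromethyl)phenyl on a sulfonyl sulfur. For the measured compounds named here, the only measured step at this place, from compound 1 to compound 2, stayed within the scatter, so no step beyond the scatter is expected in this assay for this change. The estimate therefore expects only a small step (a 1.0-fold higher number from compound 2 to compound 3 (0.00 log units; within the scatter)) here. The estimated value for compound 3 is 25000 nM with an expected range from 11000 nM to 52000 nM in this measurement.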

Compound 3, half-maximal inhibitory concentration: 10700 nM
The estimate for compound 3 lay 2.3-fold (0.37 log units) above the measured number, and the stated range ends above it.
By their numbers in this assay, from the lowest: compound 3; then compounds 2 and 1 (each within the scatter of the next).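

In this assay the sulfonyl sulfur's aryl group now proves able to move the number beyond the scatter: 4-(trifluoromethoxy)phenyl in place of 2-(trifluoromethyl)phenyl gives a 2.3-fold lower number from compound 2 to compound 3 (0.37 log units; beyond the scatter) and trifluoromethoxy in place of fluoro on an aromatic carbon gives a 3.0-fold lower number from compound 1 to compound 3 (0.48 log units; beyond the scatter) as well. Both steps are modest, yet the earlier pair showed no step beyond the scatter at this place. Nothing measured here accounts for the difference. The compounds shown leave open whether an amine or a carboxylic acid on this phenyl would lower the number further.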